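The compounds below may be only part of what the source reports. "The series", "measured", "known", "first", "only" and "open" are said of these compounds alone.

Within the data shown here, in a functional assay on the whole organism for inhibition, with Rattus norvegicus as the target (on this read-out lower numbers stand for an effect already at smaller amounts and higher numbers for an effect only at larger amounts of compound), compound 1 `CCCc1nc(C(=O)O)c(C(=O)O)n1Cc1ccc(-c2ccccc2C(=O)O)cc1` gives 0.67 mg/kg, the highest of the three numbers so far, while compound 2 `CCc1nc(CO)c(C(=O)O)n1Cc1ccc(-c2ccccc2C(=O)O)cc1` gives 0.27 mg/kg and compound 3 `CCCc1nc(CO)c(C(=O)O)n1Cc1ccc(-c2ccccc2C(=O)O)cc1` gives 0.069 mg/kg. Compound 4 `CCCc1nc(C(=O)O)c(CO)n1Cc1ccc(-c2ccccc2C(=O)O)cc1` departs from compound 1 by hydroxymethyl in place of carboxy on an aromatic carbon, on an aromatic carbon next to the ring nitrogen. Among the measured compounds shown here, the closest precedent is a 9.7-fold lower number from compound 1 to compound 3 (0.99 log units; beyond the scatter), the same exchange of groups on a different aromatic carbon. For the measured compounds named here, compound 4 thus keeps the carboxy group that compound 3 lacks and lacks the one that compound 3 keeps. The other step, a 3.9-fold lower number from compound 2 to compound 3 (0.59 log units; beyond the scatter), lies in the saturated chain, which compound 4 shares with compound 1, so it says little about this exchange. Going by the values given here, no measured compound shows the exchange on this carbon, and compound 4 is therefore not expected to reach the value of compound 3, 0.069 mg/kg. The expected 1.3-fold lower number from compound 1 to compound 4 (0.13 log units; within the scatter) would stay within the scatter in this assay. For compound 4 the estimated value is 0.5 mg/kg, with an expected range from 0.12 mg/kg to 2 mg/kg.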

Compound 4, dose for 50% inhibition: 8.8 mg/kg
Estimate against measurement, compound 4: 18-fold (1.25 log units) below; measured number above the stated range.
By their numbers in this assay, from the lowest: compound 3; then compound 2; then compound 1; then compound 4.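

In this assay, the exchange on this carbon gives a 13-fold higher number from compound 1 to compound 4 (1.12 log units; beyond the scatter), whereas the same exchange of groups on the other ring carbon gave a 9.7-fold lower number from compound 1 to compound 3 (0.99 log units; beyond the scatter). Replacing carboxy with hydroxymethyl therefore has no single direction in this series: among the compounds shown, its outcome depends on which of the two carbons of the five-membered aromatic ring carries it. Nothing shown accounts for this difference between the two carbons. The compounds shown leave open whether a primary amide, a methyl ester or a tetrazole on this carbon would stay close to compound 1 or move as far as compound 4. They also leave open whether a butyl chain in place of the propyl group would alter the size of this step.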